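The source may hold more compounds than are shown below. What is called first, only, known or untested is meant among the compounds shown, and "the series" means these compounds.

Working notes on the amide series sharing the core of compound 1 `O=C(Nc1cccc(-c2oc3cc(-c4ccc(F)cc4)ccc3c(=O)c2O)c1)c1ccccc1F`. Among the measured compounds shown here, in a functional assay on HeLa cells (Homo sapiens) for antiproliferative activity, read by CCK-8 assay, with a stated time of 72 h (a lower number here means a stronger inhibitor, a higher number a weaker inhibitor), compound 1 gives 5630 nM, the highest of the three numbers so far. Compound 2 `O=C(Nc1cccc(-c2oc3cc(-c4ccc(F)cc4)ccc3c(=O)c2O)c1)c1ccc(Cl)cc1` gives 3670 nM, and compound 3 `COc1cc(OC)cc(C(=O)Nc2cccc(-c3oc4cc(-c5ccc(F)cc5)ccc4c(=O)c3O)c2)c1` gives 2700 nM. Exchanges of the aryl group on the carbonyl carbon have so far moved the number only a little: a 1.5-fold lower number from compound 1 to compound 2 (0.19 log units; within the scatter), a 2.1-fold lower number from compound 1 to compound 3 (0.32 log units; beyond the scatter), and between the two substituted analogues a 1.4-fold lower number from compound 2 to compound 3 (0.13 log units; within the scatter).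

The unmeasured compound 4 `O=C(Nc1cccc(-c2oc3cc(-c4ccc(F)cc4)ccc3c(=O)c2O)c1)c1ccc(Cl)nc1` differs from compound 1 as follows: 6-chloropyridin-3-yl in place of 2-fluorophenyl on a carbonyl carbon. For the measured compounds named here, of the measured steps, the one from compound 1 to compound 2 bears most closely on it, since the group that enters carries chlorine in the same way as the group entering there; that step was within the scatter, and the step to compound 3 was only modest. A step of about the same small size, toward a lower number, is therefore expected, a 1.6-fold lower number from compound 1 to compound 4 (0.19 log units; within the scatter). For compound 4 in this assay the estimate is 3600 nM, between 1800 nM and 8000 nM.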

Compound 4, half-maximal inhibitory concentration: 4080 nM
For compound 4 the middle estimate is 1.1-fold (0.05 log units) below the measured one; the measured number falls inside the stated range.
By their numbers in this assay, from the lowest: compounds 3, 2, 4 and 1 (each within the scatter of the next, the first and the last beyond it).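

In this assay, the exchange of 2-fluorophenyl for 6-chloropyridin-3-yl puts a ring with one hetero atom and one hydrogen-bond acceptor on the carbonyl carbon, giving a 1.4-fold lower number from compound 1 to compound 4 (0.14 log units; within the scatter) together with a 1.1-fold higher number from compound 2 to compound 4 (0.05 log units; within the scatter) and a 1.5-fold higher number from compound 3 to compound 4 (0.18 log units; within the scatter). At this position, therefore, replacing a carbon-only aromatic ring with this pyridine ring gives no step beyond the scatter from any of the three earlier amides. No available evidence bears on the reason for this narrow spread.

As far as these compounds go, all four groups on the carbonyl carbon are six-membered aromatic rings, so the effect of a morpholine, a carboxylic acid or a longer alkyl chain there remains open. Also open, from the compounds shown here alone, is whether 6-chloropyridin-3-yl would give a similar number without its chlorine, as plain pyridin-3-yl.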